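The source may hold more compounds than are shown below. What is called first, only, known or untested is meant among the compounds shown, and "the series" means these compounds.

In an in vitro ADME assay on microsomes from liver (Homo sapiens) for metabolic stability, with a stated time of 60 min, tested at 1 uM (on this read-out lower numbers stand for slow clearance and higher numbers for fast clearance), compound 1 `CS(=O)(=O)c1ccc(-c2cnc(N)c(-c3ccc(C(F)(F)F)c(F)c3)c2)cc1` gives 14 mL.min-1.g-1. Compound 2 `CS(=O)(=O)c1ccc(-c2cnc(N)c(-c3ccc(C#N)cc3)c2)cc1` returns only a limit, < 5 mL.min-1.g-1. Compound 3 `CS(=O)(=O)c1ccc(-c2cnc(N)c(-c3ccc(S(C)(=O)=O)cc3)c2)cc1` also returns only a limit, < 5 mL.min-1.g-1, so it stands at the limit of < 5 mL.min-1.g-1 in this assay, at which 2 of the 3 values shown sit. Compound 4 `CS(=O)(=O)c1ccc(-c2cnc(N)c(-c3ccc(C(N)=O)cc3)c2)cc1` differs from compound 3 by carbamoyl in place of methylsulfonyl on an aromatic carbon, with carbamoyl in place of methylsulfonyl on an aromatic carbon. Among the compounds with values here, the one measured step that changes the group on that carbon is a step that the two limits leave unreadable from compound 2 to compound 3. It joins two limits, so it gives no size to carry over, and clearance near the limit is expected to persist. The expected change is a step that the limit leaves unreadable from compound 3 to compound 4, and no step beyond the scatter is expected in this assay. For compound 4 the estimated value is 4 mL.min-1.g-1, within an expected range of 2 mL.min-1.g-1 to 9 mL.min-1.g-1.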

Compound 4, intrinsic clearance in microsomes: < 5 mL.min-1.g-1
Compound 4: only a limit was reported; the forecaster's own chance of this, stated with the estimate: 75%; the middle value does not contradict the limit.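

In this assay compound 4 returns only a limit, so its steps from compound 2 and compound 3 cannot be read. Any real difference in clearance among these three compounds stays open, since all share one limit: the limit of < 5 mL.min-1.g-1 in this assay, at which 3 of the 4 values shown sit.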